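Aryl Swaps on a Ring Amine and Expected Binding

The compounds below may be only part of what the source reports. "The series", "measured", "known", "first", "only" and "open" are said of these compounds alone.

Measured compounds:
compound 1, `Nc1scc(CN2CCN(c3cccc(Cl)c3Cl)CC2)c1C(=O)c1ccc(Cl)cc1`: 0%
compound 2, `Nc1scc(CN2CCN(c3ccccc3C(F)(F)F)CC2)c1C(=O)c1ccc(Cl)cc1`: 0%
compound 3, `Nc1scc(CN2CCN(c3ccccc3F)CC2)c1C(=O)c1ccc(Cl)cc1`: 0%

In an assay on CHO cells for displacement of a labelled ligand from adenosine receptor A3 (Homo sapiens), read by scintillation counting, with a stated time of 120 min, tested at 10 uM (on this read-out lower numbers stand for less inhibition and higher numbers for more inhibition at the one concentration tested (going by the name of the read-out)), compound 1 gives 0%. Compound 2 gives 0%, and compound 3 gives 0%. All three share the same core and differ only in the aromatic group carried by the ring amine nitrogen. Compound 3 stands level with compounds 1 and 2; the steps of no change at the digits printed from compound 1 to compound 2 (within the scatter), no change at the digits printed from compound 1 to compound 3 (within the scatter) and no change at the digits printed from compound 2 to compound 3 (within the scatter) all show no change within the scatter.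

Compound 4, `Nc1scc(CN2CCN(c3ccc(F)c(F)c3)CC2)c1C(=O)c1ccc(Cl)cc1`, continues this series. The change from compound 3 is 3,4-difluorophenyl in place of 2-fluorophenyl on an amine nitrogen in a ring. All three measured steps bear on it, since each also swaps one aromatic group for another at this same nitrogen, and every one of them left the read-out unchanged. On that basis no step beyond the scatter is expected in this assay in either direction. Compound 4 is therefore expected to give 0%, with a range from -8% to 10%. The estimated step of no change at the digits printed from compound 3 to compound 4 (within the scatter) is expected to be none beyond the scatter.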

Compound 4, a percentage reported as inhibition, at one concentration (the size of the read-out at that concentration, not a potency): 1%
Estimate against measurement, compound 4: 1 percentage points below; the measured number falls inside the stated range.
By their numbers in this assay, from the lowest: compounds 1, 2, 3 and 4 (each within the scatter of the next).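

In this assay, 3,4-difluorophenyl puts a substitution pattern on the aryl ring that differs from those of 2-fluorophenyl, 2,3-dichlorophenyl and 2-(trifluoromethyl)phenyl, yet the read-out stays within the scatter of all three: the steps are a number 1 percentage points higher from compound 3 to compound 4 (within the scatter) and a number 1 percentage points higher from compound 2 to compound 4 (within the scatter) and a number 1 percentage points higher from compound 1 to compound 4 (within the scatter). The earlier compounds shown here showed that three aryl groups at this amine nitrogen could not be told apart at the one concentration tested, and compound 4 extends that to a fourth aryl group carrying two fluorines placed differently. No measurement shown explains why these four aryl groups read alike.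

On these data alone, with all four compounds level, it stays open whether any other group on this nitrogen could move the read-out beyond the scatter, for example a pyridine ring, a benzyl group or a plain alkyl chain in place of the substituted phenyl. Also open, as far as these compounds go, is whether an amine or a carboxylic acid on the aryl ring would read differently, and whether a change elsewhere on the shared core would matter more than any change at this nitrogen.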